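Two Near-Identical Results and a Single Methoxy Swap

The source may report more compounds than this note shows. Statements on the series, on what has been measured and on what is new or still open speak of the compounds shown alone.

Compound 1 `COc1ccc(-c2nn(-c3ccccc3)cc2CNc2ccc(F)cc2)cc1`: in a functional assay on MCF7 cells (Homo sapiens) for antiproliferative activity, read by MTT assay, with a stated time of 48 h (a higher number here means a weaker inhibitor, a lower number a stronger inhibitor), compound 1 gives 5980 nM.
Compound 2 `Brc1ccc(NCc2cn(-c3ccccc3)nc2-c2ccc(Br)cc2)cc1`: in this assay compound 2 gives 5000 nM.

Compound 2 has the lower of the two numbers, but its gap to compound 1 is within the scatter, so the two cannot be told apart. Compound 3 `COc1ccc(-c2nn(-c3ccccc3)cc2CNc2ccc(Br)cc2)cc1` has not yet been measured. It differs from compound 2 in one place: methoxy in place of bromo on an aromatic carbon. Going by the values given here, with only two measured compounds and no measured step on this change, there is no basis for expecting a step beyond the scatter in this assay in either direction. For compound 3 the estimated value is 5500 nM, with a range from 2500 nM to 12000 nM. This estimate means a step of a 1.1-fold higher number from compound 2 to compound 3 (0.04 log units; within the scatter), expected to stay within the scatter.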

Compound 3, half-maximal inhibitory concentration: 7020 nM
Beside the measured number, compound 3's estimate is 1.3-fold (0.11 log units) below it, and the stated range covers the measured number.
By their numbers in this assay, from the lowest: compounds 2, 1 and 3 (each within the scatter of the next).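

In this assay the change from 4-bromophenyl to 4-methoxyphenyl gives a 1.4-fold higher number from compound 2 to compound 3 (0.15 log units; within the scatter) and so shows that, at this position, these two groups cannot be told apart. Bromo in place of fluoro on an aromatic carbon elsewhere in the molecule gives a 1.2-fold higher number from compound 1 to compound 3 (0.07 log units; within the scatter) and likewise stays within the scatter. No supporting measurement bears on these results.

Going by these compounds, whether an amine or a carboxylic acid at the methoxy position would give a step beyond the scatter remains open. The same question stands for a longer chain such as butoxy.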